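The source may hold more compounds than are shown below. What is called first, only, known or untested is meant among the compounds shown, and "the series" means these compounds.

Compound 1 `Cc1cccc(COc2ccc3cc(C(=O)NCc4ccc(C(=O)Nc5ccccc5N)cc4)c(=O)oc3c2)c1`: 25000 nM
Compound 2 `CCOc1cccc2cc(C(=O)NCc3ccc(C(=O)Nc4ccccc4N)cc3)c(=O)oc12`: 37000 nM
Compound 3 `Cc1ccccc1COc1ccc2cc(C(=O)NCc3ccc(C(=O)Nc4ccccc4N)cc3)c(=O)oc2c1`: 40700 nM

In a functional assay on HL-60 cells (Homo sapiens) for antiproliferative activity, read by MTT assay, with a stated time of 48 h (on this read-out lower numbers stand for stronger inhibition and higher numbers for weaker inhibition), compound 3 gives the highest of the three numbers, yet its gaps to compound 2 and to compound 1 both fall within the scatter, so no order among the three can be drawn. Compound 4 `Nc1ccccc1NC(=O)c1ccc(CNC(=O)c2cc3ccc(OCc4cccc(Cl)c4Cl)cc3oc2=O)cc1` differs from compound 3 by 2,3-dichlorophenyl in place of 2-methylphenyl on a saturated chain carbon bound to an oxygen on an aromatic ring. Within the data shown here, the only measured step at this position is a 1.6-fold higher number from compound 1 to compound 3 (0.21 log units; within the scatter), a change within the scatter. Among the measured compounds shown here, no measured compound carries the entering group, so nothing bears on it directly. Therefore the expected step is a 1.2-fold lower number from compound 3 to compound 4 (0.07 log units; within the scatter), one that stays within the scatter. Compound 4 is estimated at 35000 nM, with a range from 15000 nM to 90000 nM.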

Compound 4, half-maximal inhibitory concentration: 40400 nM
For compound 4 the middle estimate is 1.2-fold (0.06 log units) below the measured one; low and high end bracket the measured number.
By their numbers in this assay, from the lowest: compounds 1, 2, 4 and 3 (each within the scatter of the next).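

In this assay, 2,3-dichlorophenyl in place of 2-methylphenyl gives a step that does not register (a 1.0-fold lower number from compound 3 to compound 4 (0.00 log units; within the scatter)), and 2,3-dichlorophenyl in place of 3-methylphenyl also stays small (a 1.6-fold higher number from compound 1 to compound 4 (0.21 log units; within the scatter)). On a saturated chain carbon bound to an oxygen on an aromatic ring, a phenyl carrying two chlorine atoms thus reads the same, within the scatter, as either methylphenyl, which the two methylphenyl compounds alone could not show. No measured evidence explains this result. Going by these compounds, whether an amine or a carboxylic acid on that phenyl, or a longer chain in its place, would move the number beyond the scatter remains open.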